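Hydrazone series: cytotoxicity outlook for the bromo analogue

The compounds below may be only part of what the source reports. "The series", "measured", "known", "first", "only" and "open" are said of these compounds alone.

The series shares one core and varies the group on the six-membered ring. Compound 1 `Cc1c(C(=O)N/N=C/c2ccc(N(C)C)cc2)no[n+]1[O-]` carries dimethylamino, and in an ADME assay on J774.1 cells (Mus musculus) for cytotoxicity, read by MTT assay, with a stated time of 48 h (on this read-out higher numbers stand for weaker inhibition and lower numbers for stronger inhibition), compound 1 gives 129000 nM. Compound 2 `Cc1c(C(=O)N/N=C/c2ccccc2)no[n+]1[O-]` has hydrogen in that place; in this assay compound 2 reaches only a limit of the assay, > 400000 nM. Compound 3 `Cc1c(C(=O)N/N=C/c2ccc(C(=O)O)cc2)no[n+]1[O-]` carries carboxy; in this assay compound 3 likewise reaches only a limit, > 300000 nM. Compound 3 thus stands at the weak end of the numbers shown, known only as a bound. The step of an at least 2.3-fold higher number from compound 1 to compound 3 (0.36 log units; beyond the scatter) is readable only as a lower bound, as is an at least 3.1-fold higher number from compound 1 to compound 2 (0.49 log units; beyond the scatter), while a step that the two limits leave unreadable from compound 2 to compound 3 rests on the limit of > 300000 nM in this assay, at which 1 of the 3 values shown sits, and the limit of > 400000 nM in this assay, at which 1 of the 3 values shown sits, and cannot be sized.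

Compound 4 `Cc1c(C(=O)N/N=C/c2ccc(Br)cc2)no[n+]1[O-]` is the next member: bromo in place of carboxy on an aromatic carbon, para to a large group. Among the measured compounds shown here, no measured step exchanges carboxy for bromo, and the readable steps of an at least 3.1-fold higher number from compound 1 to compound 2 (0.49 log units; beyond the scatter) and an at least 2.3-fold higher number from compound 1 to compound 3 (0.36 log units; beyond the scatter) only show movement away from dimethylamino toward weaker inhibition. The step that the limit leaves unreadable from compound 3 to compound 4 is therefore expected to be none beyond the scatter, with the value likely again at a limit. Compound 4 is estimated at 350000 nM, within 150000 nM to 800000 nM.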

Compound 4, half-maximal inhibitory concentration: 162000 nM
Estimate against measurement, compound 4: 2.2-fold (0.33 log units) above, and the stated range covers the measured number.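

In this assay, among the compounds shown here, bromo on this aromatic carbon, para to a large group, is the first replacement for dimethylamino whose step stays within the scatter: a 1.3-fold higher number from compound 1 to compound 4 (0.10 log units; within the scatter). Against hydrogen the change is clearer, an at least 2.4-fold lower number from compound 2 to compound 4 (0.39 log units; beyond the scatter), while against carboxy the result is weaker, an at least 1.8-fold lower number from compound 3 to compound 4 (0.26 log units; that floor lies within the scatter), so a measurable value at this place no longer depends on dimethylamino alone, yet bromo is not firmly separated from carboxy. The floor against carboxy rests on compound 3 being known only as a limit: the limit of > 300000 nM in this assay, at which 1 of the 4 values shown sits.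

The step between hydrogen and carboxy remains unreadable, and the true sizes of the steps to bromo stay unfixed. As far as these compounds go, whether chloro, methoxy or a primary amine at this place would match bromo and dimethylamino remains open.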